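Removing the Chloro Group from Compound 2

The source may hold more compounds than are shown below. What is called first, only, known or untested is meant among the compounds shown, and "the series" means these compounds.

Three related compounds share one core and differ only in the aryl group attached to it. Compound 1 `Cc1cc(O)c(C(C)C)cc1-c1cc(-c2ccccc2[N+](=O)[O-])c(C#N)c(=O)[nH]1` carries a 2-nitrophenyl group, and in a functional assay for inhibition, tested at 60 ug/mL (on this read-out lower numbers stand for a weaker effect and higher numbers for a stronger effect at the one concentration tested), compound 1 gives 31%. Compound 2 `Cc1cc(O)c(C(C)C)cc1-c1cc(-c2ccccc2Cl)c(C#N)c(=O)[nH]1` carries a 2-chlorophenyl group, and in this assay compound 2 gives 26%, the smallest of the three numbers shown, though the step of a number 5 percentage points lower from compound 1 to compound 2 (within the scatter) lies within the scatter. Compound 3 `COc1ccc(-c2cc(-c3cc(C(C)C)c(O)cc3C)[nH]c(=O)c2C#N)c(OC)c1` carries a 2,4-dimethoxyphenyl group, and in this assay compound 3 gives 48.5%; the steps of a number 17.5 percentage points higher from compound 1 to compound 3 (beyond the scatter) and a number 22.5 percentage points higher from compound 2 to compound 3 (beyond the scatter) both go beyond the scatter.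

Compound 4 `Cc1cc(O)c(C(C)C)cc1-c1cc(-c2ccccc2)c(C#N)c(=O)[nH]1` has not yet been measured. Its change from compound 2 is hydrogen in place of chloro on an aromatic carbon. The step that bears most on it is the swap of one group for another on that same aromatic carbon, from compound 1 to compound 2, which stayed within the scatter; the larger steps to compound 3 came with a change of the whole aryl group. A step of a number 2 percentage points higher from compound 2 to compound 4 (within the scatter) is therefore expected, not beyond the scatter. Compound 4 is estimated at 28%, with a range from 14% to 42%.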

Compound 4, a percentage reported as inhibition, at one concentration (the size of the read-out at that concentration, not a potency): 34%
The estimate for compound 4 lay 6 percentage points below the measured number; the measured number falls inside the stated range.
By their numbers in this assay, from the lowest: compounds 2, 1 and 4 (each within the scatter of the next); then compound 3.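

In this assay, the step of a number 8 percentage points higher from compound 2 to compound 4 (within the scatter) for losing the chloro group and the step of a number 3 percentage points higher from compound 1 to compound 4 (within the scatter) for losing the nitro group show that, on this carbon, neither group can be told apart from plain hydrogen. Only a change of the whole aryl group separates the numbers here: the step of a number 14.5 percentage points lower from compound 3 to compound 4 (beyond the scatter) sets the plain phenyl group of compound 4 apart from the 2,4-dimethoxyphenyl group of compound 3. No measurement is available that explains these numbers.

The compounds shown leave open whether one methoxy group alone, at either of the two places it holds in compound 3, would give a number like that of compound 3. They also leave open what an amine or a carboxylic acid on this ring would give.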